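This account rests on a few compounds, and the source may have more. Where it says the series, first, only, none or still open, it means among the compounds named here.

Compound 1 `Fc1cc(Cl)ccc1N1CCN(Cc2ccn3c(CC4CC4)nnc3c2C(F)(F)F)CC1` gives 7280 nM in a functional assay on HEK293 cells for agonist activity at metabotropic glutamate receptor 2 (Homo sapiens), read by a luciferase reporter and cAMP accumulation; on this read-out lower numbers stand for an effect already at smaller amounts and higher numbers for an effect only at larger amounts of compound.
Compound 2 `Fc1ccc(N2CCN(Cc3ccn4c(CC5CC5)nnc4c3C(F)(F)F)CC2)c(Cl)c1` gives 2350 nM in this assay.
Compound 3 `Fc1ccc(C2CCN(Cc3ccn4c(CC5CC5)nnc4c3C(F)(F)F)CC2)c(F)c1` gives 371 nM in this assay.

Among these three numbers compound 2 stands second highest: compound 1 gives the higher number, with the step of a 3.1-fold lower number from compound 1 to compound 2 (0.49 log units; beyond the scatter) lying beyond the scatter, while compound 3, which differs from compound 2 in more than one place, gives the lowest number of the three.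

Compound 4 `Fc1ccccc1N1CCN(Cc2ccn3c(CC4CC4)nnc3c2C(F)(F)F)CC1` has not yet been measured. It differs from compound 2 in one place: 2-fluorophenyl in place of 2-chloro-4-fluorophenyl on an amine nitrogen in a ring. Among the measured compounds shown here, the only measured step that touches this ring is a 3.1-fold lower number from compound 1 to compound 2 (0.49 log units; beyond the scatter), where the same two halogens appear in a different arrangement; no measured step removes a halogen outright. The step from compound 2 to compound 3 is not a single change and therefore offers no clean guidance. The expectation is thus a step of about a 1.3-fold higher number from compound 2 to compound 4 (0.11 log units; within the scatter), close to the scatter, with wide uncertainty. Compound 4 is accordingly estimated at 3000 nM, in a range from 900 nM to 10000 nM.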

Compound 4, half-maximal effective concentration: 2090 nM
Compound 4: the middle estimate sits 1.4-fold (0.16 log units) above what was measured; low and high end bracket the measured number.
By their numbers in this assay, from the lowest: compound 3; then compounds 4 and 2 (each within the scatter of the next); then compound 1.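

Taking the chloro off the 4-chloro-2-fluorophenyl group of compound 1 changes the result clearly, with a 3.5-fold lower number from compound 1 to compound 4 (0.54 log units; beyond the scatter), so on this ring a chloro group is not neutral wherever it sits. Yet replacing 2-chloro-4-fluorophenyl with plain 2-fluorophenyl gives a 1.1-fold lower number from compound 2 to compound 4 (0.05 log units; within the scatter), so in this assay the extra chloro and fluoro groups of compound 2 bring no measurable gain over the single fluoro group of compound 4. No measurement here explains why these two changes differ.

As far as these compounds go, it remains open whether a phenyl group with no halogen at all, or one carrying a methoxy or nitrile group, would give a similar number. Compound 3 differs from these compounds in more than one place, so which of its changes goes with its value also stays unresolved.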